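This account rests on a few compounds, and the source may have more. Where it says the series, first, only, none or still open, it means among the compounds named here.

Compound 1, `CSc1ccc(CNc2nc([SeH])nc3ccccc23)cc1`: in a functional assay on MCF7 cells (Homo sapiens) for cytotoxicity, read by MTT assay, with a stated time of 72 h (on this read-out lower numbers stand for stronger inhibition of growth and higher numbers for weaker inhibition of growth), compound 1 reaches only a limit of > 100000 nM.
Compound 2, `[SeH]c1nc(NCc2ccccc2)c2ccccc2n1`: in this assay compound 2 reaches only a limit of > 100000 nM.

Compound 1 stands at the limit of > 100000 nM in this assay, at which 2 of the 2 values shown sit, so its place is known only as a limit and not as a number. For the measured compounds named here, the one measured step, a step that the two limits leave unreadable from compound 1 to compound 2, is unreadable because both ends of it are limits and not numbers, so its size cannot be read.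

Compound 3, `CSc1ccc(CNc2nc(SC)nc3ccccc23)cc1`, differs from compound 1 in one place: a group of 2 heavy atoms (1 carbon, 1 sulfur; no ring) in place of one selenium atom, on an aromatic carbon. Going by the values given here, no measured step bears on this change; the only measured step, from one limit to another, is unreadable, and it concerns a different place on the shared core. The shared core itself gave a limit in both measured compounds. For this assay the step of a number no higher from compound 1 to compound 3 (the limit leaves the size open) is therefore expected to leave compound 3 at the limit as well. Compound 3 is estimated at 100000 nM, within 30000 nM to 100000 nM.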

Compound 3, concentration for total growth inhibition: > 100000 nM
Compound 3 was reported as a limit; the forecaster's own chance of this, stated with the estimate: 80%; the middle value sits exactly at the limit.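

Compound 3 sits at the same kind of limit as compound 1 and compound 2, so no new step can be read between compound 1 and compound 3: the limit of > 100000 nM in this assay, at which 3 of the 3 values shown sit.

In this assay the compounds shown leave open whether any change to the shared core alters growth inhibition at all.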